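The source may hold more compounds than are shown below. What is called first, only, known or untested is meant among the compounds shown, and "the series" means these compounds.

Measured compounds in an assay on isolated protein for inhibition of protein kinase C delta type (Homo sapiens), read by TR-FRET, with a stated time of 2 h; a lower number here means a stronger inhibitor, a higher number a weaker inhibitor:

Compound 1 `N#Cc1cnc(NCc2cnccc2C(F)(F)F)cc1N[C@H]1CC[C@H](O)CC1` gives 6500 nM.
Compound 2 `N#Cc1cnc(NCc2cnccc2C(F)(F)F)cc1N[C@H]1CC[C@@H](C(N)=O)CC1` gives 400 nM.
Compound 3 `CNC(=O)[C@H]1CC[C@@H](Nc2cc(NCc3cnccc3C(F)(F)F)ncc2C#N)CC1` gives 1600 nM.

Compound 3 stands second highest of the three numbers in this assay: the step of a 4.0-fold higher number from compound 2 to compound 3 (0.60 log units; beyond the scatter) puts compound 2 below it, and the step of a 4.1-fold lower number from compound 1 to compound 3 (0.61 log units; beyond the scatter) puts compound 1 above it. The largest step in the set is a 16-fold lower number from compound 1 to compound 2 (1.21 log units; beyond the scatter), so the group on the saturated ring carbon of the shared core carries most of the spread seen so far.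

Compound 4 `N#Cc1cnc(NCc2cnccc2C(F)(F)F)cc1N[C@H]1CC[C@@H](n2cncn2)CC1` differs from compound 3 in one place: 1H-1,2,4-triazol-1-yl in place of methylcarbamoyl on a saturated ring carbon. Among the measured compounds shown here, no measured step swaps an amide for an aromatic heterocycle at this position; the bearing steps only show that a hydroxyl, a primary amide and a methylamide at the same ring carbon span the whole range, with the methylamide sitting between the other two. The expected step of a 1.1-fold lower number from compound 3 to compound 4 (0.03 log units; within the scatter) is therefore uncertain and taken as none beyond the scatter, with wide room either way.

Compound 4 is estimated at 1500 nM in this assay, within a range of 400 nM to 6000 nM.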

Compound 4, half-maximal inhibitory concentration: 5500 nM
Estimate against measurement, compound 4: 3.7-fold (0.56 log units) below; low and high end bracket the measured number.
By their numbers in this assay, from the lowest: compound 2; then compound 3; then compounds 4 and 1 (each within the scatter of the next).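

In this assay, replacing either amide on the saturated ring carbon with 1H-1,2,4-triazol-1-yl costs potency, with the methylamide swap giving (a 3.4-fold higher number from compound 3 to compound 4 (0.54 log units; beyond the scatter)) and the primary amide swap giving (a 14-fold higher number from compound 2 to compound 4 (1.14 log units; beyond the scatter)). Compound 4 (5500 nM) and compound 1 (6500 nM) lie within the scatter of each other, so this position separates the two amides from the triazole and the hydroxyl across these four compounds, with no exception among them, and compound 2 remains the strongest inhibitor of the set. No measured evidence is available to explain why the triazole gives a higher number than either amide.

A carboxylic acid or a primary amine on the same ring carbon would test whether the low number of compound 2 depends on the carbonyl, the amide nitrogen or both. As far as these compounds go, a longer chain carrying the primary amide would show whether the carbamoyl must sit directly on the ring, and the reach of these steps to other groups on the shared core also remains open.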